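Swapping an Aromatic Ring for a Piperidine Ring

The source may report more compounds than this note shows. Statements on the series, on what has been measured and on what is new or still open speak of the compounds shown alone.

Compound 1 `O=C(c1cccc(F)c1)N1CC(c2nc(-c3cccc(Cl)c3)no2)C1`: > 10000 nM
Compound 2 `O=S(=O)(c1ccc(Cl)cc1)N1CC(c2nc(-c3cccc(Cl)c3)no2)C1`: > 10000 nM
Compound 3 `Cc1cccc(-c2noc(C3CN(C(=O)c4cccc(F)c4)C3)n2)c1`: > 10000 nM

In an assay on HEK293 cells for positive allosteric modulation of metabotropic glutamate receptor 5 (Homo sapiens), read by FLIPR (a higher number here means that more compound is needed for the effect, a lower number that less compound is needed), compound 1 gives > 10000 nM, which is a limit of the assay and not a number. Compound 2 gives > 10000 nM, also a limit. Compound 3 gives > 10000 nM, again a limit. Within the data shown here, the one step between measured compounds that differ in a single place, a step that the two limits leave unreadable from compound 1 to compound 3, therefore cannot be read in size or direction, because of the limit of > 10000 nM in this assay, at which 3 of the 3 values shown sit. Among the measured compounds shown here, in short, nothing measured so far tells how much any change moves this assay.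

Compound 4 `COC1CCN(C(=O)N2CC(c3nc(-c4cccc(Cl)c4)no3)C2)CC1` has not yet been measured. Compared with compound 1 it carries 4-methoxypiperidin-1-yl in place of 3-fluorophenyl on a carbonyl carbon. For the measured compounds named here, no measured step touches this part of the molecule: the step from compound 1 to compound 3 alters a different ring, and compound 2 differs from compound 1 in the linking group, with both values being limits. With all three measured values sitting at the limit, the most likely outcome is that compound 4 also reaches the limit, though a real number cannot be ruled out. Compound 4 is expected to give about 15000 nM, in the range 3000 nM to 80000 nM. The expected step is then a step that the limit leaves unreadable from compound 1 to compound 4.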

Compound 4, half-maximal effective concentration: > 10000 nM
Compound 4 ended at the assay's limit; the forecaster's own chance of this, stated with the estimate: 70%; the middle value is on the limit's open side.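

Compound 1 and compound 4 both stand at a limit of this assay, not at a number, so the step from the 3-fluorophenyl to the 4-methoxypiperidin-1-yl group cannot be read in size or direction because of this: (the limit of > 10000 nM in this assay, at which 4 of the 4 values shown sit). The compounds shown leave open whether any change to this shared core gives a real value in this assay at all.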